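The compounds below may be only part of what the source reports. "The series", "measured", "known", "first", "only" and "open" are said of these compounds alone.

Compound 1 `Cc1nnc(SCC(=O)c2ccccc2)n1N1C(=O)c2ccccc2C1=O` gives, in a functional assay on A549 cells (Homo sapiens) for cytotoxicity, read by MTT assay, with a stated time of 48 h (on this read-out lower numbers stand for stronger inhibition and higher numbers for weaker inhibition), only the assay limit > 200000 nM.
Compound 2 `CSc1nnc(C)n1N1C(=O)c2ccccc2C1=O` gives in this assay only the limit > 200000 nM.
Compound 3 `CCCc1nnc(SCC(=O)c2ccccc2)n1N1C(=O)c2ccccc2C1=O` gives in this assay only the limit > 200000 nM.

The step that the two limits leave unreadable from compound 1 to compound 2 belongs to the change (hydrogen in place of benzoyl on a saturated chain carbon bound to a sulfur). The step that the two limits leave unreadable from compound 1 to compound 3 belongs to the change (ethyl in place of hydrogen on a saturated chain carbon bound to an aromatic carbon), which is also how the core of compound 3 differs from the core of compound 1. Compound 4 `CCCc1nnc(SC)n1N1C(=O)c2ccccc2C1=O` is not yet measured; it differs from compound 3 by hydrogen in place of benzoyl on a saturated chain carbon bound to a sulfur, the same change as that from compound 1 to compound 2, at a place described in the same words. All three measured values sit at the limit of > 200000 nM in this assay, at which 3 of the 3 values shown sit, so the size of neither measured step can be read. Compound 4 is expected to show a step that the limit leaves unreadable from compound 3 to compound 4 in this assay, an expectation that rests on compounds 1, 2 and 3 all sitting at the limit of > 200000 nM in this assay, at which 3 of the 3 values shown sit. Compound 4 is therefore estimated at 250000 nM in this assay, between 100000 nM and 1000000 nM, most likely reported again only as a limit.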

Compound 4, half-maximal inhibitory concentration: > 200000 nM
Compound 4: only a limit was reported; the forecaster's own chance of this, stated with the estimate: 85%; the middle value lies beyond the limit too.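

In this assay compound 4 gives only the limit > 200000 nM. Its steps from compound 2 and compound 3 therefore cannot be read: the limit of > 200000 nM in this assay, at which 4 of the 4 values shown sit.

The compounds shown leave open what size either change, benzoyl to hydrogen or hydrogen to ethyl, would have on a measurable value.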